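Methoxy on the phenoxy ring: what to expect

This account rests on a few compounds, and the source may have more. Where it says the series, first, only, none or still open, it means among the compounds named here.

Measured so far:
compound 1 `Cc1ccccc1-n1nc(C)c2c1NC(=O)[C@H](C)S[C@@H]2c1ccc(-c2cc3ccccc3o2)cc1` — 1500 nM
compound 2 `Cc1ccccc1-n1nc(C)c2c1NC(=O)[C@H](C)S[C@@H]2c1ccc(Oc2ccccc2)cc1` — 1300 nM

Both compounds were tested in an assay on isolated protein for agonist activity at Bile acid receptor (Homo sapiens), read by AlphaScreen, with a stated time of 30 min; on this read-out lower numbers stand for an effect already at smaller amounts and higher numbers for an effect only at larger amounts of compound. Compound 2 `Cc1ccccc1-n1nc(C)c2c1NC(=O)[C@H](C)S[C@@H]2c1ccc(Oc2ccccc2)cc1` holds the lowest of the two numbers, with compound 1 closest at a distance that falls within the scatter; the step of a 1.2-fold lower number from compound 1 to compound 2 (0.06 log units; within the scatter) therefore tells nothing about direction.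

Compound 3 `COc1cccc(Oc2ccc([C@H]3S[C@@H](C)C(=O)Nc4c3c(C)nn4-c3ccccc3C)cc2)c1` differs from compound 2 by methoxy in place of hydrogen on an aromatic carbon. Among the compounds with values here, no measured step bears directly on this change: the only step on record swaps the whole aromatic group on the core, and that step was within the scatter. Because a 1.2-fold lower number from compound 1 to compound 2 (0.06 log units; within the scatter) showed no movement beyond the scatter when the group at this end of the molecule was exchanged, compound 3 is expected to stay close to compound 2, with a step of no change at the digits printed from compound 2 to compound 3 (within the scatter) of no more than the scatter. The estimate for compound 3 is 1300 nM, in a range from 450 nM to 4000 nM.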

Compound 3, half-maximal effective concentration: 1700 nM
The estimate for compound 3 lay 1.3-fold (0.12 log units) below the measured number; the range from low to high includes it.
By their numbers in this assay, from the lowest: compounds 2, 1 and 3 (each within the scatter of the next).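

In this assay, within the data shown here, this is the first change made on the phenoxy ring itself rather than an exchange of the whole group: methoxy on an aromatic carbon, meta to a large group, gives a 1.3-fold higher number from compound 2 to compound 3 (0.12 log units; within the scatter) and so does not separate the two compounds. Exchanging 1-benzofuran-2-yl for 3-methoxyphenoxy gives a 1.1-fold higher number from compound 1 to compound 3 (0.05 log units; within the scatter) on the same read-out, so none of the three end groups shown can be told apart from the others. Nothing measured here offers an explanation for how close these numbers lie.

Going by these compounds, it remains open whether a different group on this ring, such as an amine or a carboxylic acid, would shift the number beyond the scatter. On these data alone, it is also open whether methoxy would read the same on another carbon of this ring.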